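Nitro for Methyl at a Shifted Place on the Benzyl Ring

The compounds below may be only part of what the source reports. "The series", "measured", "known", "first", "only" and "open" are said of these compounds alone.

Compound 1 `Cc1cccc(Cn2cc(CO)c3ccccc32)c1` and compound 2 `Cc1ccc(Cn2cc(CO)c3ccccc32)cc1` contain the same atoms joined differently; the difference between the two cores is not broken down here. In a functional assay on NCI-H460 cells (Homo sapiens) for cytotoxicity, read by sulforhodamine B assay, with a stated time of 3 days (on this read-out lower numbers stand for stronger inhibition and higher numbers for weaker inhibition), compound 1 gives 31 nM, and compound 2 gives 31 nM, the same number at the digits shown. Compound 3 `O=[N+]([O-])c1cccc(Cn2cc(CO)c3ccccc32)c1` differs from compound 1 by nitro in place of methyl on an aromatic carbon, and compound 3 gives 39 nM in this assay; the step was a 1.3-fold higher number from compound 1 to compound 3 (0.10 log units; within the scatter). Compound 4 `O=[N+]([O-])c1ccc(Cn2cc(CO)c3ccccc32)cc1` stands to compound 2 by the same kind of change, (nitro in place of methyl on an aromatic carbon), though the place is para to a large group where in compound 3 it is meta to a large group. Because the earlier step was a 1.3-fold higher number from compound 1 to compound 3 (0.10 log units; within the scatter), for compound 4 the step is expected to be a 1.3-fold higher number from compound 2 to compound 4 (0.11 log units; within the scatter). Compound 4 is therefore estimated at 40 nM in this assay.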

Compound 4, half-maximal inhibitory concentration: 79 nM
Beside the measured number, compound 4's estimate is 2.0-fold (0.30 log units) below it; the range from low to high includes it.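

In this assay, nitro in place of methyl on an aromatic carbon, para to a large group, gives a 2.5-fold higher number from compound 2 to compound 4 (0.41 log units; beyond the scatter). Set beside the earlier step, the two results do not differ by more than the measurements can resolve, so the change carries across these two cores as far as can be told: the same change on two cores in this assay, a 1.3-fold higher number (0.10 log units; within the scatter) from compound 1 to compound 3 and a 2.5-fold higher number (0.41 log units; beyond the scatter) from compound 2 to compound 4, 2.0-fold (0.31 log units) apart, within the scatter of two such steps This does not show that the two steps are identical, and two pairs cannot show that the change would carry to any further core in the series.

The compounds shown hold only methyl and nitro in these places. As far as these compounds go, how an amine or a carboxylic acid there would read in this assay remains open.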